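The source may hold more compounds than are shown below. What is called first, only, known or untested is meant among the compounds shown, and "the series" means these compounds.

Working notes on the series, all read in a functional assay on NCI-H460 cells (Homo sapiens) for cytotoxicity, read by MTT assay, with a stated time of 72 h; a higher number here means a weaker inhibitor, a lower number a stronger inhibitor. Compound 1 `O=c1[nH]/c(=C\c2ccc(Cl)o2)c(=O)[nH]/c1=C\c1cccc(Oc2ccc(F)cc2)c1` gives 180 nM. Compound 2 `O=c1[nH]/c(=C\c2ccc([N+](=O)[O-])o2)c(=O)[nH]/c1=C\c1cccc(Oc2ccc(F)cc2)c1` gives > 1000 nM, which is a limit and not a number. Compound 3 `Cc1ccc(/C=c2\[nH]c(=O)/c(=C/c3cccc(Oc4ccc(F)cc4)c3)[nH]c2=O)o1` gives 30 nM, the lowest number shown so far. Both steps to it lie beyond the scatter: a 6.0-fold lower number from compound 1 to compound 3 (0.78 log units; beyond the scatter) and an at least 33-fold lower number from compound 2 to compound 3 (1.52 log units; beyond the scatter). The remaining measured step is an at least 5.5-fold higher number from compound 1 to compound 2 (0.74 log units; beyond the scatter).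

Next in line is compound 4 `CC(C)(C)S(=O)(=O)OCc1ccc(/C=c2\[nH]c(=O)/c(=C/c3cccc(Oc4ccc(F)cc4)c3)[nH]c2=O)o1`. The change, (((tert-butyl)sulfonyl)oxy in place of hydrogen on a saturated chain carbon bound to an aromatic carbon), turns the methyl of compound 3 into (((tert-butyl)sulfonyl)oxy)methyl. Among the compounds with values here, no measured step makes this change directly. The closest guide is that same methyl, which was reached from chloro and from nitro. With only these three compounds, methyl gives the lowest number, and neither of the other two groups goes against that. Leaving the methyl of compound 3 is therefore expected to raise the number, given the modest step from compound 1 and the large step from compound 2 shown above. A modest rise in this assay is the working expectation, with a wide margin on the upper side. The expected step is a 4.0-fold higher number from compound 3 to compound 4 (0.60 log units; beyond the scatter). For compound 4 the estimate is 120 nM, with an expected range of 30 nM to 700 nM.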

Compound 4, half-maximal inhibitory concentration: 378 nM
Compound 4: middle estimate off by 3.2-fold (0.50 log units), on the low side; the measured number falls inside the stated range.
By their numbers in this assay, from the lowest: compound 3; then compound 1; then compound 4. At a limit, above all of these: compound 2.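

In this assay, ((tert-butyl)sulfonyl)oxy in place of hydrogen gives a 13-fold higher number from compound 3 to compound 4 (1.10 log units; beyond the scatter), a large step and the first one shown on a saturated chain carbon bound to an aromatic carbon, where the earlier steps were all changes on the aromatic carbon itself. The group does not take the series out of measurable range: with (((tert-butyl)sulfonyl)oxy)methyl in place of chloro the result is a 2.1-fold higher number from compound 1 to compound 4 (0.32 log units; beyond the scatter), a modest step, so methyl stays the lowest of the substituents with a number, followed by chloro and then this longer group. With the same group in place of nitro the result is an at least 2.6-fold lower number from compound 2 to compound 4 (0.42 log units; beyond the scatter), and this step is a bound only, as the value of compound 2 is a limit and not a number: the limit of > 1000 nM in this assay, at which 1 of the 4 values shown sits.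

A single substituted example on this chain carbon gives no trend, and it cannot separate the part played by the tert-butyl from that of the sulfonyl oxygen link. On these data alone, whether a hydroxymethyl, an aminomethyl or a simple ethyl would read close to compound 3 or close to compound 4 remains open.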